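Moving One Side Chain Between Two Related Cores

This account rests on a few compounds, and the source may have more. Where it says the series, first, only, none or still open, it means among the compounds named here.

Compound 1 `CO/N=C(\C)COc1ccc2oc(-c3ccccc3)cc(=O)c2c1`: 800000 nM
Compound 2 `CO/N=C(\C)COc1ccc2c(=O)c(-c3ccccc3)coc2c1`: 6400000 nM
Compound 3 `O=c1cc(-c2ccccc2)oc2ccc(OC/C(=N/O)c3ccccc3)cc12`: 700000 nM

All three were tested in a functional assay on SK-HEP1 cells (Homo sapiens) for antiproliferative activity; on this read-out higher numbers stand for weaker inhibition of growth and lower numbers for stronger inhibition of growth. Compound 1 and compound 2 are built from the same atoms joined differently; the difference between their two cores is not broken down here. Compound 2 gives the highest number of the three, and its steps to compound 1 and to compound 3 both lie beyond the scatter. Compound 3 keeps the core of compound 1 and carries a changed side chain: a group of 9 heavy atoms (7 carbon, 1 nitrogen, 1 oxygen; one six-membered aromatic ring of carbon only) in place of a group of 5 heavy atoms (3 carbon, 1 nitrogen, 1 oxygen; no ring), on a saturated chain carbon bound to an oxygen on an aromatic ring. This change gave a 1.1-fold lower number from compound 1 to compound 3 (0.06 log units; within the scatter).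

Compound 4 `O=c1c(-c2ccccc2)coc2cc(OC/C(=N/O)c3ccccc3)ccc12` has not yet been measured in this assay. It keeps the core of compound 2 and carries the same change: a group of 9 heavy atoms (7 carbon, 1 nitrogen, 1 oxygen; one six-membered aromatic ring of carbon only) in place of a group of 5 heavy atoms (3 carbon, 1 nitrogen, 1 oxygen; no ring), on a saturated chain carbon bound to an oxygen on an aromatic ring. The place of the change reads the same in both pairs, so it is the same change made on a second core. For compound 4 the expected step is a 1.1-fold lower number from compound 2 to compound 4 (0.04 log units; within the scatter), resting on the measured step of a 1.1-fold lower number from compound 1 to compound 3 (0.06 log units; within the scatter). The estimate for compound 4 is 5800000 nM, with 2000000 nM and 15000000 nM as the likely range.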

Compound 4, concentration for 50% growth inhibition: 6400000 nM
Estimate against measurement, compound 4: 1.1-fold (0.04 log units) below, within the range that was stated.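

In this assay, replacing the side chain on the core of compound 2 gave no change at the digits printed from compound 2 to compound 4 (within the scatter), and the same replacement behaved alike on the two cores: the same change on two cores in this assay, a 1.1-fold lower number (0.06 log units; within the scatter) from compound 1 to compound 3 and no change at the digits printed (within the scatter) from compound 2 to compound 4, 1.1-fold (0.06 log units) apart, within the scatter of two such steps

Going by these compounds alone, this shows that, for these two pairs, the replacement carries from one core to the other with the same outcome: no step that can be told apart from the scatter. It does not show that the side chain never matters in this series, since two pairs on two cores cannot speak for other cores or for other groups at this place.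

As far as these compounds go, whether an amine, a carboxylic acid or a longer chain on the saturated chain carbon bound to an oxygen on an aromatic ring would give a step beyond the scatter, on either core, stays open. The entering group also brings its aromatic ring and its hydrogen-bond donor together, so what each of the two would do alone is open as well.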